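The source may report more compounds than this note shows. Statements on the series, on what has been measured and on what is new or still open speak of the compounds shown alone.

Measured in a functional assay on A549 cells (Homo sapiens) for cytotoxicity, read by MTT assay, with a stated time of 72 h; on this read-out lower numbers stand for stronger inhibition and higher numbers for weaker inhibition:

- compound 1 `CC(C)OC1OC(=O)C(Cl)=C1N1CCCCC1` gives > 400000 nM (a limit of the assay, not a number)
- compound 2 `CC(C)OC1OC(=O)C(Cl)=C1Cl` gives 6700 nM
- compound 3 `CCCOC1OC(=O)C(Cl)=C1Cl` gives 3600 nM

Only compound 2 and compound 3 give actual numbers, and these two lie within the scatter of each other, so compound 3 stands level with compound 2. Compound 1 has only its limit to offer.

The next compound to be tested is compound 4 `CC(C)(C)COC1OC(=O)C(Cl)=C1Cl`, which alters the chain on the oxygen of compound 3: tert-butyl in place of ethyl on a saturated chain carbon bound to an oxygen on a saturated carbon. Among the compounds with values here, the one measured step that changes the group on this oxygen is a 1.9-fold lower number from compound 2 to compound 3 (0.27 log units; within the scatter). Swapping isopropyl for propyl therefore left the number within the scatter. Compound 1 carries the same isopropyl group as compound 2, so its limit says nothing about a change to this group.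

On that single step, no shift beyond the scatter is expected in either direction. Within the data shown here, no measured compound carries a tert-butyl group, so the expected range is kept wide. The estimated change is a 1.1-fold higher number from compound 3 to compound 4 (0.05 log units; within the scatter). Compound 4 is expected at about 4000 nM, with an estimated range from 1500 nM to 11000 nM.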

Compound 4, half-maximal inhibitory concentration: 7700 nM
Compound 4: the middle estimate sits 1.9-fold (0.28 log units) below what was measured; the range from low to high includes it.
By their numbers in this assay, from the lowest: compounds 3, 2 and 4 (each within the scatter of the next, the first and the last beyond it). At a limit, above all of these: compound 1.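

The chain on this oxygen can move the number after all. In this assay, within the data shown here, the only earlier step at this place, a 1.9-fold lower number from compound 2 to compound 3 (0.27 log units; within the scatter), stayed within the scatter and so could not show whether the group here matters at all. Among these compounds, putting tert-butyl in place of ethyl on a saturated chain carbon bound to an oxygen on a saturated carbon gives a 2.1-fold higher number from compound 3 to compound 4 (0.33 log units; beyond the scatter) and is the first step at this place to pass beyond the scatter, though only modestly and towards weaker inhibition. The data shown offer no measured reason for this step, so it stands as an observation without an explanation.

As far as these compounds go, a longer unbranched chain such as pentyl on the same oxygen would help to tell whether the step follows the branching of tert-butyl or simply the larger group, and that question stays open here. Also open is what an amine or a carboxylic acid at the end of this chain would do to the number in this assay, since every chain shown here is built of carbon alone.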